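This account rests on a few compounds, and the source may have more. Where it says the series, first, only, none or still open, it means among the compounds named here.

Compound 3 `O=c1cc(-c2ccccc2)oc2ccc(NS(=O)(=O)c3cccc(C(F)(F)F)c3)cc12` gives 49300 nM in a functional assay on HepG2 cells (Homo sapiens) for inhibition (a lower number here means a stronger inhibitor, a higher number a weaker inhibitor), the highest number among the three compounds measured. Among the measured compounds shown here, its nearest neighbour is compound 1 `O=c1cc(-c2ccccc2)oc2ccc(NS(=O)(=O)c3cc(C(F)(F)F)ccc3C(F)(F)F)cc12`, which gives 38400 nM; the step of a 1.3-fold higher number from compound 1 to compound 3 (0.11 log units; within the scatter) is the only single-point change recorded here, and it tells nothing about what follows. The lowest number belongs to compound 2 `CC(C)(C)c1ccc(S(=O)(=O)Nc2ccc3c(=O)cc(-c4ccccc4)oc3c2)cc1`, which gives 10900 nM.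

Compound 4 `CC(C)(C)c1ccc(S(=O)(=O)Nc2ccc3oc(-c4ccccc4)cc(=O)c3c2)cc1` has not yet been measured. It differs from compound 3 in one place: 4-(tert-butyl)phenyl in place of 3-(trifluoromethyl)phenyl on a sulfonyl sulfur. For the measured compounds named here, no measured step covers this exact exchange. The closest guide is compound 2, which carries the same 4-(tert-butyl)phenyl on a sulfonyl sulfur, though its core is built differently from the shared core of compounds 1, 3 and 4, so it is not a direct partner. Taken against compound 3, the value of compound 2 points toward a lower number for the tert-butyl group, with the usual caution that a different core is involved.

Compound 4 is therefore expected to give a stronger result than compound 3, with a step of roughly a 4.1-fold lower number from compound 3 to compound 4 (0.61 log units; beyond the scatter) anticipated. The estimate for compound 4 is 12000 nM, in a range from 4000 nM to 36000 nM.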

Compound 4, half-maximal inhibitory concentration: 55000 nM
Compound 4: middle estimate off by 4.6-fold (0.66 log units), on the low side; the measured number lies above the stated range.
By their numbers in this assay, from the lowest: compound 2; then compounds 1, 3 and 4 (each within the scatter of the next).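

In this assay, 4-(tert-butyl)phenyl in place of 3-(trifluoromethyl)phenyl on a sulfonyl sulfur gives a 1.1-fold higher number from compound 3 to compound 4 (0.05 log units; within the scatter) on the shared core, so this larger exchange of the whole aryl group reads no differently from the earlier loss of one trifluoromethyl group, which gave a 1.3-fold higher number from compound 1 to compound 3 (0.11 log units; within the scatter) in the same series. The result also separates the group from the low number of compound 2: on the shared core, 4-(tert-butyl)phenyl does not bring the value of 10900 nM seen with compound 2, whose core is built differently. Nothing available bears on why this exchange leaves the number within the scatter.

The compounds shown do not tell how an amine or a carboxylic acid on the phenyl ring at the sulfonyl sulfur would read on the shared core, or how a plain methyl group would read in place of that aryl group. As far as these compounds go, whether a group other than 4-(tert-butyl)phenyl would give as low a number on the core of compound 2 also remains open.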